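Swapping a trifluoromethyl for a methoxy on a styryl chromone

This account rests on a few compounds, and the source may have more. Where it says the series, first, only, none or still open, it means among the compounds named here.

Compound 1 `COc1cc(OC)c2c(=O)cc(/C=C/c3ccncc3)oc2c1`: 18800 nM
Compound 2 `COc1cc(OC)c2c(=O)cc(/C=C/c3ccc(Cl)cc3)oc2c1`: 14200 nM
Compound 3 `COc1cc(OC)c2c(=O)cc(/C=C/c3ccc(C(F)(F)F)cc3)oc2c1`: 19000 nM

Of the compounds shown here, three sharing one core have been tested in a functional assay on HeLa cells (Homo sapiens) for antiproliferative activity, read by MTT assay, with a stated time of 12 h (on this read-out higher numbers stand for weaker inhibition and lower numbers for stronger inhibition), differing only in the aromatic group at the end of the two-carbon linker. In this assay compound 1 gives 18800 nM. Putting a 4-chlorophenyl in place of the pyridin-4-yl gives a 1.3-fold lower number from compound 1 to compound 2 (0.12 log units; within the scatter). Replacing the chloro with a trifluoromethyl then gives a 1.3-fold higher number from compound 2 to compound 3 (0.13 log units; within the scatter). Both steps stay within the scatter, so compound 3 cannot be told apart from compound 1 or compound 2 on these numbers; the three stand together.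

Compound 4 `COc1ccc(/C=C/c2cc(=O)c3c(OC)cc(OC)cc3o2)cc1` carries the change (methoxy in place of trifluoromethyl on an aromatic carbon). For the measured compounds named here, no measured step swaps exactly these two groups, but the closest comparison is the step from compound 2 to compound 3, where one group on the same aromatic carbon was traded for another and nothing beyond the scatter followed. The pyridyl-to-chlorophenyl step was equally flat. With three quiet steps and no sign that this position moves the read-out, compound 4 is expected to land among its neighbours, with a 1.2-fold lower number from compound 3 to compound 4 (0.07 log units; within the scatter) expected as essentially no change beyond the scatter. The estimate for compound 4 in this assay is 16000 nM, within 7000 nM to 36000 nM.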

Compound 4, half-maximal inhibitory concentration: 17800 nM
Beside the measured number, compound 4's estimate is 1.1-fold (0.05 log units) below it; the measured number falls inside the stated range.
By their numbers in this assay, from the lowest: compounds 2, 4, 1 and 3 (each within the scatter of the next).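

The swap removes a trifluoromethyl of 4 heavy atoms with no hydrogen-bond acceptor and puts in a methoxy of 2 heavy atoms with 1 hydrogen-bond acceptor, yet this assay shows only a 1.1-fold lower number from compound 3 to compound 4 (0.03 log units; within the scatter) for this change. Set against the other two end groups, the new compound again shows no separation, with a 1.3-fold higher number from compound 2 to compound 4 (0.10 log units; within the scatter) against the chloro compound and a 1.1-fold lower number from compound 1 to compound 4 (0.02 log units; within the scatter) against the pyridin-4-yl compound, so the flat picture now also covers a group that brings an oxygen onto this aromatic carbon and all four compounds stand together. Nothing available here explains why the read-out stays so flat.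

Still open, from the compounds shown here alone, is whether any group on this aromatic carbon can move the read-out beyond the scatter, as an amine, a carboxylic acid or a longer chain such as butoxy might or might not do. Also open, going by these compounds, is whether the two methoxy groups on the shared core, which all four compounds keep, have any bearing on the read-out.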